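The compounds below may be only part of what the source reports. "The series", "measured", "known", "first", "only" and "open" are said of these compounds alone.

Measured so far in an assay on HEK293 cells for displacement of a labelled ligand from 5-hydroxytryptamine receptor 7 (Homo sapiens), with a stated time of 1 h; a higher number here means a weaker inhibitor, a lower number a stronger inhibitor:
- compound 1 `COc1ccccc1N1CCN(CCCCC(=O)N2CCC[C@H]2C(N)=O)CC1`: 634 nM
- compound 2 `NC(=O)[C@@H]1CCCN1C(=O)CCCCCN1CCN(c2ccc(F)cc2)CC1`: 1190 nM

For the measured compounds named here, compound 2 has the higher of the two numbers recorded in this assay, but its only neighbour, compound 1, lies within the usual scatter of the measurement, so the two values cannot be placed in any order; they are best read as the same level of binding.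

Compound 3 `NC(=O)[C@@H]1CCCN1C(=O)CCCCCN1CCN(c2noc3ccccc23)CC1` has not yet been measured. It differs from compound 2 in one place: a group of 9 heavy atoms (7 carbon, 1 nitrogen, 1 oxygen; one five-membered aromatic ring with 2 hetero atoms, one six-membered aromatic ring of carbon only) in place of a group of 7 heavy atoms (6 carbon, 1 fluorine; one six-membered aromatic ring of carbon only), on an amine nitrogen in a ring. Going by the values given here, no pair of measured compounds shows a change of this kind, so there is no measured step to lean on, and the direction of the change is open. On the basis of the two values that exist, a step of moderate size is expected, more likely toward a lower number than a higher one, though a result that stays within the scatter of compound 2 would not be surprising. The estimated step is a 3.0-fold lower number from compound 2 to compound 3 (0.47 log units; beyond the scatter). Compound 3 is accordingly estimated at 400 nM, with a range from 100 nM to 1600 nM.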

Compound 3, inhibition constant: 50 nM
Compound 3: the middle estimate sits 8.0-fold (0.90 log units) above what was measured; the whole stated range lies above it.
By their numbers in this assay, from the lowest: compound 3; then compounds 1 and 2 (each within the scatter of the next).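

In this assay, the group on the amine nitrogen in a ring proves able to change binding strongly: exchanging 4-fluorophenyl for the group with a five-membered aromatic ring with 2 hetero atoms and a six-membered aromatic ring of carbon only gives a 24-fold lower number from compound 2 to compound 3 (1.38 log units; beyond the scatter). For the compounds shown here, this is the first measured step that changes one place alone, and it shows that the rest of compound 2 can be kept unchanged while this single exchange moves the value well beyond the scatter. The exchange alters the ring count, the heavy atoms and the hydrogen-bond acceptors together, and no measurement at hand explains the gain.

The compounds shown cannot separate these features, so it remains open whether a plain phenyl group or a single five-membered aromatic ring with 2 hetero atoms on the same nitrogen would keep any of the gain. Also open, going by these compounds, is whether the gain would carry over to a longer chain, or to a carboxylic acid in place of the amide on the ring that bears the large group.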